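Swapping a trifluoromethyl for chloro on the aryl urea

The compounds below may be only part of what the source reports. "The series", "measured", "known", "first", "only" and "open" are said of these compounds alone.

Compound 3 `COc1cc(NC(C)CCCNC(=O)NNC(=O)Nc2cccc(C(F)(F)F)c2)c2ncccc2c1` was tested in a functional assay on MCF7 cells (Homo sapiens) for inhibition, read by MTT assay, with a stated time of 72 h (a higher number here means a weaker inhibitor, a lower number a stronger inhibitor), where it gives 190 nM. Among the three measured compounds it holds the second highest number: compound 1 `COc1cc(NC(C)CCCNC(=O)NNC(=O)Nc2cccc(F)c2)c2ncccc2c1` gives 150 nM, and the two differ only by a 1.3-fold higher number from compound 1 to compound 3 (0.10 log units; within the scatter), whereas compound 2 `COc1cc(NC(C)CCCNC(=O)Nc2ccc(O)cc2)c2ncccc2c1` gives 5200 nM, reached from compound 1 by a 35-fold higher number from compound 1 to compound 2 (1.54 log units; beyond the scatter). The untested compound 4 `COc1cc(NC(C)CCCNC(=O)NNC(=O)Nc2cccc(Cl)c2)c2ncccc2c1` changes compound 3 at a single aromatic carbon: chloro in place of trifluoromethyl on an aromatic carbon. Among the compounds with values here, the only step touching the same aromatic carbon is a 1.3-fold higher number from compound 1 to compound 3 (0.10 log units; within the scatter), which stayed within the scatter, so no step beyond the scatter is expected here, in either direction, giving the estimate a 1.1-fold lower number from compound 3 to compound 4 (0.05 log units; within the scatter). Compound 4 is therefore expected to give about 170 nM, with a range from 80 nM to 400 nM.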

Compound 4, half-maximal inhibitory concentration: 220 nM
The estimate for compound 4 lay 1.3-fold (0.11 log units) below the measured number; the measured number falls inside the stated range.
By their numbers in this assay, from the lowest: compounds 1, 3 and 4 (each within the scatter of the next); then compound 2.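

In this assay, this aromatic carbon has now carried fluoro, chloro and trifluoromethyl with no readable difference: a 1.2-fold higher number from compound 3 to compound 4 (0.06 log units; within the scatter) and a 1.5-fold higher number from compound 1 to compound 4 (0.17 log units; within the scatter) both stay within the scatter, so one chlorine atom here matches the four heavy atoms of trifluoromethyl. The large gap to the 4-hydroxyphenyl urea also holds for the chloro compound, at a 24-fold lower number from compound 2 to compound 4 (1.37 log units; beyond the scatter). No measured evidence bears on why these three groups read alike.

As far as these compounds go, whether an amine or a carboxylic acid on this same aromatic carbon would leave the number unchanged remains open, as does what a plain phenyl with no group there would give.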